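The source may hold more compounds than are shown below. What is called first, only, known or untested is meant among the compounds shown, and "the series" means these compounds.

Series on a shared core carried by compound 1 `CCCCCCCCc1ccc(OCC(=O)Cn2nnc(-c3ccncc3)n2)cc1` and compound 2 `CCCCCCCCc1ccc(OCC(=O)Cn2nnc(-c3cccnc3)n2)cc1`. In an assay on microsomes from brain for inhibition of Fatty-acid amide hydrolase 1 (Rattus norvegicus), read by fluorescence and HPLC, with a stated time of 60 min (a higher number here means a weaker inhibitor, a lower number a stronger inhibitor), compound 1 gives 24 nM, and compound 2 gives 23 nM. The change between them is pyridin-3-yl in place of pyridin-4-yl on an aromatic carbon, and the step it made, a 1.0-fold lower number from compound 1 to compound 2 (0.02 log units; within the scatter), is flat. Compound 3 `CCCCCCCCc1ccc(OCC(=O)Cn2nnnc2-c2ccncc2)cc1` has a different core; how its core differs from that of compound 1 is not broken down here. In this assay compound 3 gives 190 nM, a number well apart from those of compound 1 and compound 2. Compound 4 `CCCCCCCCc1ccc(OCC(=O)Cn2nnnc2-c2cccnc2)cc1` is not yet measured; it relates to compound 3 by pyridin-3-yl in place of pyridin-4-yl on an aromatic carbon. Within the data shown here, this is the same kind of change as the one in the earlier pair, not the same: here the aromatic carbon is next to the ring atom that bears a large group, whereas earlier it was two ring bonds from the ring atom that bears a large group. The expectation for compound 4 rests on the flat step a 1.0-fold lower number from compound 1 to compound 2 (0.02 log units; within the scatter). On that basis a near-nil step is expected, a 1.1-fold lower number from compound 3 to compound 4 (0.02 log units; within the scatter), though the different place leaves room for departure. Compound 4 is thus estimated at 180 nM in this assay, within a range from 80 nM to 400 nM.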

Compound 4, half-maximal inhibitory concentration: 190 nM
For compound 4 the middle estimate is 1.1-fold (0.02 log units) below the measured one, and the stated range covers the measured number.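

Replacing pyridin-4-yl with pyridin-3-yl on the core of compound 3 gives no change at the digits printed from compound 3 to compound 4 (within the scatter) in this assay, so the flat result seen on the core of compound 1 recurs on this second core. Set side by side, the two steps show no difference between the cores: the same change on two cores in this assay, a 1.0-fold lower number (0.02 log units; within the scatter) from compound 1 to compound 2 and no change at the digits printed (within the scatter) from compound 3 to compound 4, 1.0-fold (0.02 log units) apart, within the scatter of two such steps This shows that, for these two pairs, the swap can be carried from one core to the other with the same flat outcome, but it does not show that a change with a step beyond the scatter would carry over in the same way, and it says nothing about why the two cores stand apart.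

From the compounds shown here alone, whether the flat outcome holds with a phenyl in place of the pyridine ring, or with a carboxylic acid or an amine carried on that ring, stays open. Also open, going by these compounds, is how a shorter chain in place of the octyl chain would read on either core in this assay.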